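The source may hold more compounds than are shown below. What is called first, only, known or untested is meant among the compounds shown, and "the series" means these compounds.

Measured compounds in an assay on microsomes from liver for inhibition of sterol O-acyltransferase 1 (Rattus norvegicus); on this read-out lower numbers stand for stronger inhibition and higher numbers for weaker inhibition:
compound 1 `CCCCCCn1nc(-c2ccccc2)c(-c2ccccc2)cc1=O` gives 57000 nM
compound 2 `CCCCCCCn1nc(-c2ccccc2)c(-c2ccccc2)cc1=O` gives 86000 nM
compound 3 `CCCCCCNc1cc(-c2ccccc2)c(-c2ccccc2)nn1` gives 24000 nM

Among these three numbers compound 3 stands lowest; its gaps to compound 1 and to compound 2 both lie beyond the usual scatter. Compound 4 `CCCCCCCSc1cc(-c2ccccc2)c(-c2ccccc2)nn1` differs from compound 3 in one place: heptylsulfanyl in place of hexylamino on an aromatic carbon. Going by the values given here, only one measured step bears on this change, and only in part: a 1.5-fold higher number from compound 1 to compound 2 (0.18 log units; within the scatter), which lengthens a saturated chain by one carbon and stays within the scatter. Among the compounds with values here, the exchange of the nitrogen-bound hydrogen for sulfur has no counterpart among the measured compounds, so its effect cannot be read from them. The chain extension alone gives no reason to expect a step beyond the scatter, and the remainder is an open question. On this basis compound 4 is expected to stay close to compound 3, with the estimated step of a 1.3-fold higher number from compound 3 to compound 4 (0.10 log units; within the scatter). The estimate for compound 4 in this assay is 30000 nM, in a range from 10000 nM to 90000 nM.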

Compound 4, half-maximal inhibitory concentration: 76000 nM
Estimate against measurement, compound 4: 2.5-fold (0.40 log units) below; measured number inside the range.
By their numbers in this assay, from the lowest: compound 3; then compounds 1, 4 and 2 (each within the scatter of the next).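

In this assay, heptylsulfanyl in place of hexylamino on the aromatic carbon next to the ring nitrogen gives a step beyond the scatter (a 3.2-fold higher number from compound 3 to compound 4 (0.50 log units; beyond the scatter)), so the group at this position does affect the read-out. Going by these compounds alone, the only earlier step on a chain (a 1.5-fold higher number from compound 1 to compound 2 (0.18 log units; within the scatter)) stays within the scatter, but it lengthens the chain alone, whereas the new step changes the linking atom and the chain length together, and the two contributions cannot be separated. Nothing available explains the rise in the number.

The compounds shown leave open how heptylamino and hexylsulfanyl would read at this position, and these two groups would separate the linking atom from the chain length. They also leave open whether hexyloxy or a shorter chain such as butylamino would stay close to compound 3.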